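The source may report more compounds than this note shows. Statements on the series, on what has been measured and on what is new or still open speak of the compounds shown alone.

Compound 1 `O=C(CN1CCN(c2nnc(Cc3ccccc3)c3ccccc23)CC1)Nc1c(F)cccc1F` is the weakest of the three measured compounds in a functional assay on A549 cells (Homo sapiens) for cytotoxicity, read by MTT assay, with a stated time of 72 h; on this read-out higher numbers stand for weaker inhibition and lower numbers for stronger inhibition: compound 1 gives 84500 nM, while compound 2 `O=C(CN1CCN(c2nnc(Cc3ccncc3)c3ccccc23)CC1)Nc1ccc(Br)cc1` gives 2710 nM and compound 3 `Cc1cccc(Cl)c1NC(=O)CN1CCN(c2nnc(Cc3ccncc3)c3ccccc23)CC1` gives 7190 nM. Compound 4 `O=C(CN1CCN(c2nnc(Cc3ccccc3)c3ccccc23)CC1)Nc1cccc(Br)c1` differs from compound 1 by a single change (3-bromophenyl in place of 2,6-difluorophenyl on an amide-type nitrogen). Among the measured compounds shown here, no measured step shares this exact change. For the measured compounds named here, the only measured step that touches the same position, a 2.7-fold higher number from compound 2 to compound 3 (0.42 log units; beyond the scatter), sits on a different core and changes other groups, so it only suggests that the aryl group on the amide nitrogen can shift the value moderately. Compound 4 is therefore expected to move modestly, with the direction uncertain; the estimate is a 2.8-fold lower number from compound 1 to compound 4 (0.45 log units; beyond the scatter), giving compound 4 an expected 30000 nM in this assay, in a range from 7000 nM to 100000 nM.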

Compound 4, half-maximal inhibitory concentration: "not active" (no number reported)
Nothing numeric was reported for compound 4; the estimate stays without a comparison.
By their numbers in this assay, from the lowest: compound 2; then compound 3; then compound 1.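

In this assay, among the compounds shown here, compound 4 carries no number, and no step from compound 1 to compound 4 can be read. No evidence bears on this result. The compounds shown leave open how 3-bromophenyl compares numerically with 2,6-difluorophenyl on the amide-type nitrogen.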